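A few compounds are considered here, and "the series" means these few. Any claim that something is new, unique, unknown or untested is made for them only; others in the source may bear on it.

Working notes on the series.

Three analogues sharing the same bis-aminopyrimidine-linked benzothiazole core have numbers in a functional assay on HCT-116 cells (Homo sapiens) for antiproliferative activity, read by MTT assay, with a stated time of 48 h; a higher number here means a weaker inhibitor, a lower number a stronger inhibitor. Compound 1 `CS(=O)(=O)c1ccc(Nc2ncc(F)c(Nc3nc4ccccc4s3)n2)cc1` gives 3270 nM in this assay . Compound 3 `NS(=O)(=O)c1ccc(Nc2ncc(F)c(Nc3nc4ccc(Cl)cc4s3)n2)cc1` gives 8620 nM. Compound 2 `Cc1cnc(Nc2ccc([N+](=O)[O-])cc2)nc1Nc1nc2ccccc2s1`, the compound of interest here, gives 6330 nM. Its nearest neighbour by number is compound 3, and its furthest is compound 1; both gaps lie within the scatter of repeated measurements, so no order among the three can be read from these values.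

Compound 4 `Cc1cnc(Nc2ccc(F)cc2)nc1Nc1nc2ccccc2s1` is not yet measured. Relative to compound 2 the change is fluoro in place of nitro on an aromatic carbon, para to a large group. Going by the values given here, no measured pair in the set isolates this change, so the size of the step cannot be taken from the data. The expectation is a step from compound 2 to compound 4 that stays within the scatter or at most slightly beyond it, in either direction, with a 1.2-fold lower number from compound 2 to compound 4 (0.06 log units; within the scatter) as the working guess. On that basis compound 4 is estimated at 5500 nM in this assay , with a range from 2000 nM to 16000 nM.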

Compound 4, half-maximal inhibitory concentration: > 50000 nM
Compound 4: only a limit was reported (the forecaster's own chance of this, stated with the estimate: 10%); middle value at least 9.0-fold (0.95 log units) from the limit.
By their numbers in this assay, from the lowest: compounds 1, 2 and 3 (each within the scatter of the next, the first and the last beyond it). At a limit, above all of these: compound 4.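

With the 4-nitrophenyl of compound 2 exchanged for the 4-fluorophenyl of compound 4, this assay shows an at least 7.8-fold higher number from compound 2 to compound 4 (0.89 log units; beyond the scatter), so this position para to a large group is not indifferent to the group it carries. Going by these compounds alone, the earlier compounds held no pair differing in one place, which makes this the first single change whose step can be read, and it lies beyond the scatter. Compound 4 has only a limit, so the step has a floor and no measured size: the limit of > 50000 nM in this assay, at which 1 of the 4 values shown sits.

Open, going by these compounds, is whether nitro is specifically needed here or other groups on this aromatic carbon would also hold the activity; an amine, a nitrile or a carboxylic acid there would test that. Also open, on these data alone, is whether the same exchange gives a similar step on other members.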